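Chloro for Ethyl on the Aryl Ring: a Second Look

This account rests on a few compounds, and the source may have more. Where it says the series, first, only, none or still open, it means among the compounds named here.

Measured compounds:
- compound 1, `CCc1ccccc1N1CCCC(=O)N1`, 39000 nM
- compound 2, `CCc1ccc(N2CCCC(=O)N2)cc1`, 125000 nM
- compound 3, `O=C1CCCN(c2ccccc2Cl)N1`, 99000 nM

All three were tested in an assay on isolated protein for inhibition of Polyunsaturated fatty acid 5-lipoxygenase (Homo sapiens); on this read-out higher numbers stand for weaker inhibition and lower numbers for stronger inhibition. Compound 1 and compound 2 are built from the same atoms joined differently; how their two cores differ is not broken down here. Compound 3 arises from compound 1 by one change, (chloro in place of ethyl on an aromatic carbon), and that change gave a 2.5-fold higher number from compound 1 to compound 3 (0.40 log units; beyond the scatter). Compound 2 sits at the high end of the three numbers; its gap to compound 3 lies within the scatter, while its gap to compound 1 lies beyond it.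

The unmeasured compound 4, `O=C1CCCN(c2ccc(Cl)cc2)N1`, is related to compound 2 by chloro in place of ethyl on an aromatic carbon. Among the measured compounds shown here, this is the same kind of change as the one from compound 1 to compound 3, but not the same: in the earlier pair the place is ortho to a group of 7 heavy atoms, here it is para to a group of 7 heavy atoms. Starting from compound 2 in this assay, the step from compound 2 to compound 4 is expected to be roughly a 2.0-fold higher number from compound 2 to compound 4 (0.30 log units; within the scatter), resting on the single earlier step of a 2.5-fold higher number from compound 1 to compound 3 (0.40 log units; beyond the scatter) and on compound 2 giving 125000 nM; with only one precedent, this is a loose expectation. Compound 4 is therefore estimated at 250000 nM, with a likely range from 100000 nM to 600000 nM.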

Compound 4, half-maximal inhibitory concentration: 79000 nM
For compound 4 the middle estimate is 3.2-fold (0.50 log units) above the measured one; the measured number lies below the stated range.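

In this assay, the swap of ethyl for chloro does not carry over from one core to the other as a fixed step: the new step, a 1.6-fold lower number from compound 2 to compound 4 (0.20 log units; within the scatter), stays within what repeat measurements would scatter by, and the two steps differ by more than that scatter allows: the same change on two cores in this assay, a 2.5-fold higher number (0.40 log units; beyond the scatter) from compound 1 to compound 3 and a 1.6-fold lower number (0.20 log units; within the scatter) from compound 2 to compound 4, 4.0-fold (0.60 log units) apart, beyond the scatter of two such steps

A newcomer might expect one swap to shift the number by a similar amount wherever it is made, but in this small series that simple addition fails, so the step seen on one core is a poor guide to the step on the other. What this does not show is the reason for the mismatch: the two pairs differ in the core and in where the swap sits on the aromatic ring, and two pairs cannot separate those influences or establish a rule for further cores.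

The compounds shown leave open how a longer chain, an amine or a carboxylic acid would behave in place of ethyl on each core. They also leave open whether fluoro or bromo would follow chloro, or would show a different difference between the two cores.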